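This account rests on a few compounds, and the source may have more. Where it says the series, first, only, none or still open, it means among the compounds named here.

Measured so far:
compound 1 `COc1cc(-c2nn(-c3cccc(NC(=O)c4cccc(C(F)(F)F)c4)c3)cc2-c2ccncc2)ccc1Cl` — 1550 nM
compound 2 `COc1cc(-c2nn(-c3cccc(NC(=O)c4ccc(Cl)c(C(F)(F)F)c4)c3)cc2-c2ccncc2)ccc1Cl` — 3250 nM

In a functional assay on HCT-15 cells (Homo sapiens) for inhibition, read by sulforhodamine B assay, with a stated time of 48 h (on this read-out higher numbers stand for weaker inhibition of growth and lower numbers for stronger inhibition of growth), compound 2 gives 3250 nM, the higher of the two numbers, while compound 1 gives 1550 nM. Compound 3 `COc1cc(-c2nn(-c3cccc(NC(=O)c4ccccc4)c3)cc2-c2ccncc2)ccc1Cl` differs from compound 2 by phenyl in place of 4-chloro-3-(trifluoromethyl)phenyl on a carbonyl carbon. Among the compounds with values here, only one measured step bears on this: a 2.1-fold higher number from compound 1 to compound 2 (0.32 log units; beyond the scatter), which covers the chloro alone. Nothing measured covers the loss of the trifluoromethyl, so that part is open. Compound 3 is therefore expected to undo the chloro step and land near compound 1, with wide uncertainty: an estimated 1500 nM, range 500 nM to 4500 nM, an expected step of a 2.2-fold lower number from compound 2 to compound 3 (0.34 log units; beyond the scatter).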

Compound 3, concentration for 50% growth inhibition: 654 nM
Beside the measured number, compound 3's estimate is 2.3-fold (0.36 log units) above it; the range from low to high includes it.
By their numbers in this assay, from the lowest: compound 3; then compound 1; then compound 2.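

In this assay, taking away the trifluoromethyl alone gives a 2.4-fold lower number from compound 1 to compound 3 (0.37 log units; beyond the scatter), so, among these compounds, this group goes with weaker growth inhibition. Taking away the chloro and the trifluoromethyl together gives a 5.0-fold lower number from compound 2 to compound 3 (0.70 log units; beyond the scatter), which makes the plain phenyl on the carbonyl carbon the strongest of the three. Nothing measured here explains why these groups weaken the effect. Going by these compounds, it remains open whether the plain phenyl is the best choice, since a phenyl carrying a fluorine, a methoxy or an amine could move the number either way.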